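The compounds below may be only part of what the source reports. "The series", "measured", "known", "first", "only" and "open" are said of these compounds alone.

In a functional assay on CHO cells for antagonist activity at metabotropic glutamate receptor 5 (Rattus norvegicus), read by calcium flux (on this read-out lower numbers stand for stronger inhibition and higher numbers for weaker inhibition), three compounds have been measured:

Compound 1 `N#Cc1cccc(-c2ccc3cccnc3n2)c1` gives 115 nM.
Compound 2 `Cc1cccc(-c2ccc3cccnc3n2)c1` gives 225 nM.
Compound 3 `N#Cc1cccc(-c2cnc3cccnc3c2)c1` gives 18600 nM.

Compound 1 and compound 2 differ in one place: methyl in place of cyano on an aromatic carbon. This change made a 2.0-fold higher number from compound 1 to compound 2 (0.29 log units; within the scatter). Compound 3 is built from the same atoms as compound 1 joined differently; the difference between the two cores is not broken down here, and compound 3 stands well apart from both with the weakest inhibition of the three.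

Compound 4 `Cc1cccc(-c2cnc3cccnc3c2)c1` has not yet been measured. For the measured compounds named here, it differs from compound 3 by methyl in place of cyano on an aromatic carbon, the same change at the same place as the one from compound 1 to compound 2. Because a 2.0-fold higher number from compound 1 to compound 2 (0.29 log units; within the scatter) stayed within the usual scatter, a step of similar size is expected for compound 4, namely a 1.9-fold higher number from compound 3 to compound 4 (0.27 log units; within the scatter). Compound 4 is therefore estimated at 35000 nM, most likely between 12000 nM and 100000 nM.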

Compound 4, half-maximal inhibitory concentration: 15700 nM
For compound 4 the middle estimate is 2.2-fold (0.35 log units) above the measured one, and the stated range covers the measured number.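

In this assay methyl in place of cyano gave a 1.2-fold lower number from compound 3 to compound 4 (0.07 log units; within the scatter) and so left the number within the scatter on this second core as well. Set side by side, the two steps do not differ: the same change on two cores in this assay, a 2.0-fold higher number (0.29 log units; within the scatter) from compound 1 to compound 2 and a 1.2-fold lower number (0.07 log units; within the scatter) from compound 3 to compound 4, 2.3-fold (0.37 log units) apart, within the scatter of two such steps. This shows that the swap behaved alike on these two cores, but it does not show that it would do so on any other core, and steps this small cannot reveal a true effect of the swap.

The compounds shown leave open whether another group at this place, such as an amine, a carboxylic acid or a longer chain, would move the number beyond the scatter. Only cyano and methyl appear here, so that question stays unanswered on both cores.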